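This account rests on a few compounds, and the source may have more. Where it says the series, first, only, none or still open, it means among the compounds named here.

In a functional assay on MV4-11 cells (Homo sapiens) for inhibition, read by luminescence, with a stated time of 3 days (on this read-out lower numbers stand for stronger inhibition of growth and higher numbers for weaker inhibition of growth), compound 1 (`CC[C@@H]1CC[C@@H](C(=O)N2CCOCC2)N1C(=O)C1=C(C(C)C)N2C(=N[C@@](C)(c3ccc(Cl)cc3)[C@H]2c2ccc(Cl)cc2)S1`) gives 94 nM and compound 2 (`CC[C@@H]1CC[C@@H](C(=O)N2CCN(C)[C@@H](C)C2)N1C(=O)C1=C(C(C)C)N2C(=N[C@@](C)(c3ccc(Cl)cc3)[C@H]2c2ccc(Cl)cc2)S1`) gives 250 nM as the higher of the two numbers. Within the data shown here, the one measured step (a 2.7-fold higher number from compound 1 to compound 2 (0.42 log units; beyond the scatter)) is modest and beyond the scatter, with 3,4-dimethylpiperazin-1-yl in place of morpholin-4-yl on a carbonyl carbon. Compound 3 (`CC[C@@H]1CC[C@@H](C(=O)N2CCN(C(C)=O)[C@H](C)C2)N1C(=O)C1=C(C(C)C)N2C(=N[C@@](C)(c3ccc(Cl)cc3)[C@H]2c2ccc(Cl)cc2)S1`) changes that same place again (a group of 10 heavy atoms (7 carbon, 2 nitrogen, 1 oxygen; one six-membered non-aromatic ring with 2 hetero atoms) in place of a group of 8 heavy atoms (6 carbon, 2 nitrogen; one six-membered non-aromatic ring with 2 hetero atoms), on a carbonyl carbon), keeping the six-membered non-aromatic ring with 2 hetero atoms and adding 1 double bond outside aromatic rings. Among the measured compounds shown here, the step from compound 1 (a 2.7-fold higher number from compound 1 to compound 2 (0.42 log units; beyond the scatter)) is the only guide, and it is a single pair. A step of similar modest size is therefore expected in this assay toward a lower number, though the direction remains uncertain. The expected move (a 2.3-fold lower number from compound 2 to compound 3 (0.36 log units; beyond the scatter)) would return part of the way toward compound 1. For compound 3 the estimated value is 110 nM with an expected range of 45 nM to 280 nM in this read-out.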

Compound 3, concentration for 50% growth inhibition: 220 nM
The estimate for compound 3 lay 2.0-fold (0.30 log units) below the measured number, within the range that was stated.
By their numbers in this assay, from the lowest: compound 1; then compounds 3 and 2 (each within the scatter of the next).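

Working notes on the group on the carbonyl carbon: in this assay, exchanging 3,4-dimethylpiperazin-1-yl for the group of 10 heavy atoms, which adds a double bond outside aromatic rings, gives no resolved change (a 1.1-fold lower number from compound 2 to compound 3 (0.06 log units; within the scatter)), so this exchange does not recover the number of compound 1. The gap to morpholin-4-yl remains (a 2.3-fold higher number from compound 1 to compound 3 (0.37 log units; beyond the scatter)), and both groups in compounds 2 and 3, each larger than morpholin-4-yl, give numbers beyond the scatter from compound 1. No supporting data bear on the reason for this result.

Still open, going by these compounds, is whether an open-chain amine such as dimethylamino, or a smaller ring such as pyrrolidine, on this carbonyl carbon would match or improve on compound 1. Also open, on these data alone, is whether a carboxylic acid carried on the ring would shift the number in either direction.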